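The source may hold more compounds than are shown below. What is called first, only, known or untested is meant among the compounds shown, and "the series" means these compounds.

Compound 1, `C/C(=N\Cc1ccccn1)c1c(O)c2ccccc2oc1=O`: 22000 nM
Compound 2, `C/C(=N\C(C)C)c1c(O)c2ccccc2[nH]c1=O`: >= 100000 nM

In an assay on isolated protein for inhibition of myosin-2 (Bos taurus), read by spectrophotometry, with a stated time of 24 min (on this read-out higher numbers stand for weaker inhibition and lower numbers for stronger inhibition), compound 1 gives 22000 nM. For compound 2 only a limit of the assay is reported, >= 100000 nM, so compound 2 stands at the limit of >= 100000 nM in this assay, at which 1 of the 2 values shown sits, and its true value is not known. Compound 3, `CCCCC/N=C(\C)c1c(O)c2ccccc2[nH]c1=O`, is still to be measured. It differs from compound 2 by pentyl in place of isopropyl on a double-bonded nitrogen. Among the compounds with values here, no measured pair carries this change, so nothing here points in either direction, and any shift in this assay is expected to stay within the usual scatter. Compound 3 is expected to give about 100000 nM, between 30000 nM and 300000 nM. The step this means, a number no higher from compound 2 to compound 3 (the limit leaves the size open), is expected to be none beyond scatter.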

Compound 3, half-maximal inhibitory concentration: >= 100000 nM
Compound 3 gave a limit, no number; the forecaster's own chance of this, stated with the estimate: 60%; the middle value sits exactly at the limit.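

Compound 2 and compound 3 both stand at a limit of the assay, so no step can be read between them: the limit of >= 100000 nM in this assay, at which 2 of the 3 values shown sit.

The compounds shown leave open whether pentyl in place of isopropyl on a double-bonded nitrogen changes inhibition at all.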